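Terminal pyrimidinyl ether removal in a sulfonamide series

This account rests on a few compounds, and the source may have more. Where it says the series, first, only, none or still open, it means among the compounds named here.

Measured compounds:
compound 1, `COc1cccc(Oc2c(NS(=O)(=O)c3ccc(C(C)(C)C)cc3)ncnc2OCCOc2ncc(C)cn2)c1`, an assay on cells (Endothelial cell) for binding affinity to Endothelin-1 receptor (Sus scrofa); a lower number here means a stronger inhibitor, a higher number a weaker inhibitor: 0.86 nM
compound 2, `Cc1ccc(-c2c(NS(=O)(=O)c3ccc(C(C)(C)C)cc3)ncnc2OCCOc2ncc(Cl)cn2)cc1`, this assay: < 0.001 nM

Compound 1 gives 0.86 nM in this assay. For compound 2 the assay reports only a limit, < 0.001 nM, so its affinity is not known as a number; it sits at the limit of < 0.001 nM in this assay, at which 1 of the 2 values shown sits. Within the data shown here, compound 1 and compound 2 differ from each other in more than one place, so the pair carries no single attributable step; the two values show only that both compounds sit low in the range, with compound 2 at the floor of what the assay resolves.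

Compound 3 `Cc1ccc(-c2c(NS(=O)(=O)c3ccc(C(C)(C)C)cc3)ncnc2OCCO)cc1` follows from compound 2 by hydrogen in place of 5-chloropyrimidin-2-yl on an oxygen on a saturated carbon. Among the measured compounds shown here, no measured pair in the set isolates this change. Because compound 2 stands at a limit, the step to compound 3 cannot be read against a number, only against the floor. The expectation is a loss of binding in this assay, well beyond the usual scatter, with a step expected at an at least 10000-fold higher number from compound 2 to compound 3 (4.00 log units; beyond the scatter). Compound 3 is estimated at 10 nM, with a range from 0.5 nM to 200 nM.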

Compound 3, half-maximal inhibitory concentration: > 100 nM
Compound 3: no number, only a limit; the forecaster's own chance of this, stated with the estimate: 5%; at least 10-fold (1.00 log units) between middle value and limit.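

Among these compounds, this is the one pair that differs in a single place, and in this assay hydrogen in place of 5-chloropyrimidin-2-yl on an oxygen on a saturated carbon gives an at least 100000-fold higher number from compound 2 to compound 3 (5.00 log units; beyond the scatter). On these data alone, both ends of this pair are limits of the assay, so the step is a bound and its true size remains unknown: the limit of > 100 nM in this assay, at which 1 of the 3 values shown sits. The 5-chloropyrimidin-2-yl group on this oxygen therefore carries a large share of the binding of compound 2, and the 2-hydroxyethyl end of compound 3 does not stand in for the 2-((5-chloropyrimidin-2-yl)oxy)ethyl end.

The compounds shown leave open whether the two ring nitrogens matter or any aromatic ring would serve, as a phenyl or a pyridin-2-yl on the same oxygen would show, and whether a simple methyl ether or a longer chain ending in an amine would keep part of the binding. The chlorine of compound 2 also stays unseparated from the methyl on the same ring in compound 1, as these two compounds differ in more than one place.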